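From Fluoro to Methoxy: Expected Cytotoxicity of Compound 3

The compounds below may be only part of what the source reports. "The series", "measured", "known", "first", "only" and "open" are said of these compounds alone.

Within the data shown here, compound 2 `O=C(/C=C/c1ccc2c(c1)B(O)OC2)c1cccc(F)c1` holds the only number so far in a toxicity assay on WI-38 cells (Homo sapiens) for cytotoxicity, read by MTT assay, with a stated time of 48 h (a higher number here means a weaker inhibitor, a lower number a stronger inhibitor), giving 26700 nM. Compound 1 `O=C(/C=C/c1ccc2c(c1)B(O)OC2)c1ccc(O)cc1` reaches only a limit there, at > 100000 nM. Compound 3 `COc1cccc(C(=O)/C=C/c2ccc3c(c2)B(O)OC3)c1` differs from compound 2 by methoxy in place of fluoro on an aromatic carbon. Among the measured compounds shown here, the single measured step, an at least 3.7-fold lower number from compound 1 to compound 2 (0.57 log units; beyond the scatter), concerns a different group and rests on the limit (the limit of > 100000 nM in this assay, at which 1 of the 2 values shown sits), so it gives little guidance for a methoxy in place of a fluoro. Compound 3 is therefore expected to change little, with a step of a 1.1-fold higher number from compound 2 to compound 3 (0.05 log units; within the scatter) staying within the scatter. Compound 3 is estimated at 30000 nM, ranging from 10000 nM to 100000 nM.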

Compound 3, half-maximal inhibitory concentration: 14600 nM
Estimate against measurement, compound 3: 2.1-fold (0.31 log units) above; measured number inside the range.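

In this assay, among these compounds, the step of a 1.8-fold lower number from compound 2 to compound 3 (0.26 log units; within the scatter) is the first here to join two numbers rather than a number and a limit. On an aromatic carbon meta to a large group, methoxy and fluoro thus cannot be told apart in this reading. The earlier step gave no such direct comparison, and one value remains a limit: the limit of > 100000 nM in this assay, at which 1 of the 3 values shown sits.

The compounds shown leave open whether an amine or a carboxylic acid on this carbon would give a step beyond the scatter. They also leave open how methoxy would read on another carbon of the same ring.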